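A few compounds are considered here, and "the series" means these few. Any claim that something is new, unique, unknown or untested is made for them only; others in the source may bear on it.

Measured so far:
compound 1 `NC(=O)N(O)CC1=Cc2cc(OCC3CCCCC3)ccc2OC1` with 1360 nM
compound 2 `NC(=S)N(O)CC1=Cc2cc(Oc3ccccc3)ccc2OC1` with 180 nM

In an assay (Cavia porcellus) for inhibition of Polyunsaturated fatty acid 5-lipoxygenase (Homo sapiens) (a higher number here means a weaker inhibitor, a lower number a stronger inhibitor), compound 2 gives 180 nM, the lowest of the two numbers; compound 1 gives 1360 nM, a gap beyond the scatter. Compound 3 `CCOC(=O)CNC(=O)N(O)CC1=Cc2cc(Oc3ccccc3)ccc2OC1` is not yet measured. Its change from compound 2 is a group of 9 heavy atoms (5 carbon, 1 nitrogen, 3 oxygen; no ring) in place of a group of 3 heavy atoms (1 carbon, 1 nitrogen, 1 sulfur; no ring), on an amine nitrogen. Among the measured compounds shown here, no measured pair shows this change, so the size of the step rests on the change alone. The step from compound 2 to compound 3 is expected to raise the number, by more than the scatter: a 3.9-fold higher number from compound 2 to compound 3 (0.59 log units; beyond the scatter). Compound 3 is therefore estimated at 700 nM, with a range from 200 nM to 2500 nM.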

Compound 3, half-maximal inhibitory concentration: 68 nM
Compound 3: the middle estimate sits 10-fold (1.01 log units) above what was measured; measured number below the stated range.
By their numbers in this assay, from the lowest: compound 3; then compound 2; then compound 1.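

In this assay, the amine nitrogen accepts ((ethoxycarbonyl)methyl)carbamoyl in place of the group of 3 heavy atoms, a far larger group, and the number still falls: a 2.6-fold lower number from compound 2 to compound 3 (0.42 log units; beyond the scatter). The change swaps sulfur for a carbonyl oxygen and adds the ester chain in one step, so the shift cannot be divided between those two parts. Nothing at hand bears on the reason for this shift.

Which part carries the step stays open. So does the effect of a carboxylic acid in place of the ethyl ester, or of a longer chain, at this position.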